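The source may report more compounds than this note shows. Statements on the series, on what has been measured and on what is new or still open speak of the compounds shown alone.

Compound 1 `COc1cncc(C2=CC3CC(C2)CN(C)C3)c1`, compound 2 `COc1cc(C2=CC3CC(C2)CN(C)C3)cnc1Cl` and compound 3 `Clc1ccc(Oc2cncc(C3=CC4CNCC(C3)C4)c2)cc1` have all been tested in an in vitro assay on SH-EP1 cells for displacement of a labelled ligand from Neuronal acetylcholine receptor; alpha4/beta2 (Homo sapiens); on this read-out higher numbers stand for weaker inhibition and lower numbers for stronger inhibition. Compound 1 gives 0.6 nM, compound 2 gives 4.4 nM, and compound 3 gives 1.9 nM. Compounds 2 and 1 differ in a single place: hydrogen in place of chloro on an aromatic carbon. That one change made a 7.3-fold lower number from compound 2 to compound 1 (0.87 log units; beyond the scatter). How the core of compound 3 differs from the core of compound 2 is not broken down here; the values alone show that compound 3 stands between the other two, beyond the scatter on each side.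

Compound 4 `C1=C(c2cncc(Oc3ccccc3)c2)CC2CNCC1C2` has not yet been measured in this assay. It differs from compound 3 in one place: hydrogen in place of chloro on an aromatic carbon. Among the compounds with values here, this is the same kind of change as the one from compound 2 to compound 1, but not the same: in the earlier pair the chloro sat on a six-membered aromatic ring with one nitrogen, next to the ring nitrogen and ortho to a methoxy group, whereas here it sits on a six-membered aromatic ring of carbon only, para to a large group. The earlier step is therefore only a loose guide. In this assay compound 4 is expected to give about 1.2 nM, most likely between 0.4 nM and 4 nM. This estimate corresponds to a step of a 1.6-fold lower number from compound 3 to compound 4 (0.20 log units; within the scatter), a smaller move than the earlier one, resting on compound 3 giving 1.9 nM as the starting point and on the different surroundings of the chloro that is removed.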

Compound 4, inhibition constant: 0.7 nM
Compound 4: middle estimate off by 1.7-fold (0.23 log units), on the high side; the measured number falls inside the stated range.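

In this assay, putting hydrogen in place of chloro gave a 2.7-fold lower number from compound 3 to compound 4 (0.43 log units; beyond the scatter), so the number fell on both cores, but the size of the fall did not carry over: the same change on two cores in this assay, a 7.3-fold lower number (0.87 log units; beyond the scatter) from compound 2 to compound 1 and a 2.7-fold lower number (0.43 log units; beyond the scatter) from compound 3 to compound 4, 2.7-fold (0.43 log units) apart, beyond the scatter of two such steps

For this series, then, the earlier pair pointed the right way, yet its step could not be moved as a fixed amount onto a new core. Two pairs are still a very small sample, and they do not show why the steps differ in size, since the cores differ and the chloro also sits on a different ring in each pair, so these compounds cannot separate those influences.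

The compounds shown leave open how the phenyl ring of compound 4 responds to other groups on an aromatic carbon in the place named here, on a six-membered aromatic ring of carbon only, para to a large group, such as a fluoro, an amine or a carboxylic acid. They also leave open whether the same hydrogen-for-chloro change would lower the number on further cores, or whether these two pairs merely happen to agree in direction.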